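The source may report more compounds than this note shows. Statements on the series, on what has been measured and on what is new or still open speak of the compounds shown alone.

Working notes on the triazene series.

Compound 1 `FC(F)(F)c1cccc(/N=N/c2ccc(NC[C@@H]3CCCN4CCCC[C@H]34)c3c2CCCC3)c1` gives 50000 nM in an ADME assay on Vero cells (Chlorocebus sabaeus) for cytotoxicity, read by crystal violet staining; a higher number here means that more compound is tolerated, a lower number that less compound is tolerated. Compound 2 `Cc1ccc(/N=N/N(C)c2ccccc2)cc1` gives 58000 nM, and compound 3 `Cc1ccc(/N=N/N(CCCN(C)C)c2ccccc2)cc1` gives 100000 nM. The number for compound 3 lies within the scatter of both others, so nothing separates the three on this assay. Among the measured compounds shown here, the one measured step, a 1.7-fold higher number from compound 2 to compound 3 (0.24 log units; within the scatter), concerns the saturated chain on the triazene nitrogen, and it stays inside the scatter.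

Compound 4 `CN(C)CCCN(/N=N/c1ccc([N+](=O)[O-])cc1)c1ccccc1` differs from compound 3 in a single place: nitro in place of methyl on an aromatic carbon. For the measured compounds named here, no measured step touches the aromatic carbon where the change sits, so the only guidance is the flatness of the three numbers so far and the small size of the chain step from compound 2 to compound 3. On that basis the step from compound 3 to compound 4 is expected to be a 1.4-fold lower number from compound 3 to compound 4 (0.15 log units; within the scatter), i.e. none beyond the scatter. The estimate for compound 4 in this assay is 70000 nM, with an expected range from 25000 nM to 160000 nM.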

Compound 4, half-maximal cytotoxic concentration: 40000 nM
Estimate against measurement, compound 4: 1.8-fold (0.24 log units) above, and the stated range covers the measured number.
By their numbers in this assay, from the lowest: compounds 4, 1, 2 and 3 (each within the scatter of the next, the first and the last beyond it).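

In this assay the aromatic carbon para to a large group is the only place among those shown where a single change goes beyond the scatter: nitro in place of methyl gives a 2.5-fold lower number from compound 3 to compound 4 (0.40 log units; beyond the scatter) and so less compound is tolerated, whereas the chain change gave a 1.7-fold higher number from compound 2 to compound 3 (0.24 log units; within the scatter) and stayed inside it. The step is modest, and it comes with three heavy atoms and two hydrogen-bond acceptors entering where methyl held one heavy atom and none. Nothing at hand explains this step.

Whether the step belongs to nitro itself or to any replacement of methyl on this carbon stays open, since an amine, a carboxylic acid or a chlorine there is not among the compounds shown. Also open, from the compounds shown here alone, is whether nitro gives a similar step when the saturated chain on the triazene nitrogen is a plain methyl.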